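The source may report more compounds than this note shows. Statements on the series, on what has been measured and on what is new or still open speak of the compounds shown alone.

Series notes. Compound 1 `CCN(CC)C(=O)Cc1c(-c2ccc(OC(C)C)cc2)nn2c(C)cc(C)nc12` gives 2.2 nM in an assay on isolated protein (kidney, strain Wistar) for displacement of a labelled ligand from Translocator protein (Rattus norvegicus), read by scintillation counting, with a stated time of 90 min; a lower number here means a stronger inhibitor, a higher number a weaker inhibitor. Compound 2 `CCN(CC)C(=O)Cc1c(-c2ccc(OCc3ccccc3C(F)(F)F)cc2)nn2c(C)cc(C)nc12` gives 1.4 nM in this assay; the step of a 1.6-fold lower number from compound 1 to compound 2 (0.20 log units; within the scatter) shows that 2-(trifluoromethyl)benzyl in place of isopropyl on the oxygen on the aromatic ring left the number essentially unchanged. For the measured compounds named here, compound 2 holds the lowest of the two numbers measured so far, with compound 1 sitting within the scatter of it, so no order between the two is claimed. Compound 3 `CCN(CC)C(=O)Cc1c(-c2ccc(OCCc3ccccc3)cc2)nn2c(C)cc(C)nc12` differs from compound 2 by benzyl in place of 2-(trifluoromethyl)phenyl on a saturated chain carbon bound to an oxygen on an aromatic ring; read one bond further out, 2-(trifluoromethyl)benzyl becomes phenethyl. Going by the values given here, no measured step bears directly on this exchange; the only step measured at this position, a 1.6-fold lower number from compound 1 to compound 2 (0.20 log units; within the scatter), stayed within the scatter, and on that basis a further exchange of the group on this oxygen is expected to move the number little. For compound 3 the expected step is a 1.4-fold higher number from compound 2 to compound 3 (0.15 log units; within the scatter), none beyond the scatter. Compound 3 is therefore estimated at 2 nM in this assay, with a range from 0.7 nM to 6 nM.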

Compound 3, inhibition constant: 0.13 nM
Estimate against measurement, compound 3: 15-fold (1.19 log units) above; the measured number lies below the stated range.
By their numbers in this assay, from the lowest: compound 3; then compounds 2 and 1 (each within the scatter of the next).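

In this assay the group on this oxygen clearly matters, since an 11-fold lower number from compound 2 to compound 3 (1.03 log units; beyond the scatter) and a 17-fold lower number from compound 1 to compound 3 (1.23 log units; beyond the scatter) are both large steps, whereas the earlier exchange at this position stayed within the scatter. Phenethyl therefore stands apart from both isopropyl and 2-(trifluoromethyl)benzyl, two groups that cannot be told apart by their numbers here. No measurement is available that would explain this separation.

The step from 2-(trifluoromethyl)benzyl to phenethyl both removes the trifluoromethyl group and lengthens the chain to the phenyl ring, and the compounds shown do not separate these two changes. Plain benzyl and 2-(trifluoromethyl)phenethyl on this oxygen would separate them, while 3-phenylpropyl would test whether a longer chain continues the trend.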